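Removing the methyl next to the ring nitrogen in compound 2

The source may report more compounds than this note shows. Statements on the series, on what has been measured and on what is new or still open speak of the compounds shown alone.

Measured so far:
compound 1 `Cc1ccnc(/C(N)=N/NC(=S)N2CCOCC2)c1`: 38500 nM
compound 2 `Cc1cccc(/C(N)=N/NC(=S)N2CCSCC2)n1`: 1800 nM
compound 3 `Cc1ccnc(/C(N)=N/NC(=S)N2CCN(c3ccccn3)CC2)c1`: 10500 nM

In a functional assay on HeLa cells (Homo sapiens) for cytotoxicity, read by MTT assay, with a stated time of 72 h (a lower number here means a stronger inhibitor, a higher number a weaker inhibitor), compound 2 gives the lowest number of the three and stands apart: compound 3 sits at 10500 nM and compound 1 at 38500 nM, both beyond the scatter from compound 2. For the measured compounds named here, compound 1 and compound 3 differ from compound 2 in more than one place, so neither pair isolates a single change, and no single-point step between measured compounds exists in this set.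

Compound 4 `N/C(=N\NC(=S)N1CCSCC1)c1ccccn1` is the next entry. Against compound 2 the change is hydrogen in place of methyl on an aromatic carbon. Nothing measured here shows what loss of this methyl does; the bulk of the molecule is unchanged, so a step within or near the scatter is expected, with a slight lean toward a weaker result. The step from compound 2 to compound 4 is estimated at a 1.4-fold higher number from compound 2 to compound 4 (0.14 log units; within the scatter). Compound 4 is therefore expected to give about 2500 nM, within a range of 800 nM to 8000 nM.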

Compound 4, half-maximal inhibitory concentration: 7800 nM
Beside the measured number, compound 4's estimate is 3.1-fold (0.49 log units) below it; measured number inside the range.
By their numbers in this assay, from the lowest: compound 2; then compounds 4 and 3 (each within the scatter of the next); then compound 1.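

For the compounds shown here, this is the first comparison that isolates a single change. In this assay, hydrogen in place of methyl on an aromatic carbon next to the ring nitrogen gives a 4.3-fold higher number from compound 2 to compound 4 (0.64 log units; beyond the scatter), so the number is sensitive to this position, and the methyl goes with the lower value. Nothing measured explains this step.

Still open, as far as these compounds go, is how this carbon responds to an ethyl group, a methoxy group or a chlorine atom, and so whether the methyl is the best of the possible substituents or merely better than hydrogen. Also open, from the compounds shown here alone, is whether the same step would hold with the other end of the molecule taken from compound 1 or compound 3, since a single pair cannot show this.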